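The compounds below may be only part of what the source reports. "The series", "measured", "known", "first", "only" and "open" are said of these compounds alone.

Measured so far in an in vivo ADME assay on the whole organism for pharmacokinetics, with Rattus norvegicus as the target, at a dose of 0.5 mg/kg by the intravenous route; a higher number here means faster removal of the compound, a lower number slower removal:
- compound 1 `CC(=O)Nc1cc(-c2c(Nc3cc[nH]n3)nc3cccnn23)nc(C)n1`: 43.3 mL/min/kg
- compound 2 `Cc1nc(Nc2cccnc2)cc(-c2c(Nc3cc[nH]n3)nc3cccnn23)n1`: "not determined" (no result reported)
- compound 3 `CNc1cc(-c2c(Nc3cc[nH]n3)nc3cccnn23)nc(C)n1`: 80 mL/min/kg

Compound 3 stands highest of the two numbers in this assay; its nearest neighbour is compound 1, and the step of a 1.8-fold higher number from compound 1 to compound 3 (0.27 log units; within the scatter) lies within the scatter, so the two compounds cannot be ordered against each other. Compound 2 gives no number in this assay and adds nothing to the placing.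

The next compound, compound 4 `Cc1nccc(-c2c(Nc3cc[nH]n3)nc3cccnn23)n1`, differs from compound 3 in one place: hydrogen in place of methylamino on an aromatic carbon. The change sits on an aromatic carbon of a six-membered aromatic ring with 2 nitrogen and removes the methylamino group altogether.

For the measured compounds named here, the only measured step, a 1.8-fold higher number from compound 1 to compound 3 (0.27 log units; within the scatter), exchanges one group on a nitrogen on an aromatic ring for another and keeps that nitrogen; no measured pair removes the whole group. That step lay within the scatter, so the series has so far shown no shift in this assay beyond the scatter from changes at this position. Going by the values given here, no step bears directly on the loss of the group. The expectation for compound 4 is therefore no step beyond the scatter, a 1.1-fold lower number from compound 3 to compound 4 (0.03 log units; within the scatter), with wide uncertainty. Compound 4 is estimated at 75 mL/min/kg, with a range from 35 mL/min/kg to 150 mL/min/kg.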

Compound 4, clearance: 31.7 mL/min/kg
For compound 4 the middle estimate is 2.4-fold (0.37 log units) above the measured one; measured number below the stated range.
By their numbers in this assay, from the lowest: compounds 4, 1 and 3 (each within the scatter of the next, the first and the last beyond it).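

In this assay, for the compounds shown here, losing the methylamino group from the aromatic carbon of the six-membered aromatic ring with 2 nitrogen gives the first step at this position beyond the scatter, a 2.5-fold lower number from compound 3 to compound 4 (0.40 log units; beyond the scatter), though only a modest one. Losing the acetamido group from the same place gives a 1.4-fold lower number from compound 1 to compound 4 (0.14 log units; within the scatter), which stays within the scatter, so removing the group does not move the number beyond the scatter in both cases, and the outcome depends on which group leaves. With compound 1 within the scatter of both compound 3 and compound 4, only these last two can be told apart, and nothing at hand bears on what lies behind that difference.

On these data alone, it remains open whether the step is tied to a nitrogen attached at this place, which a methoxy group or an ethyl chain there would test, and whether a dimethylamino group would stand with methylamino or with hydrogen. Also open, as far as these compounds go, is whether the step would hold with a different group in place of the methyl group on the same ring, such as a longer chain.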